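This account rests on a few compounds, and the source may have more. Where it says the series, first, only, none or still open, it means among the compounds named here.

Working notes on the series, read in a functional assay on MCF7 cells (Homo sapiens) for inhibition, read by CCK-8 assay, with a stated time of 48 h; on this read-out higher numbers stand for weaker inhibition of growth and lower numbers for stronger inhibition of growth. Compound 1 `Cc1ccccc1Nc1nc(Nc2ccccc2)ncc1Cl` reads > 100000 nM, which is a limit of the assay. Compound 2 `Cc1ccccc1Nc1nc(Nc2ccc(N3CCCN(C)CC3)cc2)ncc1Cl` gives 4290 nM. For the measured compounds named here, the only measured step is an at least 23-fold lower number from compound 1 to compound 2 (1.36 log units; beyond the scatter). Compound 3 `CN1CCN(c2ccc(Nc3ncc(Cl)c(NCc4ccccc4)n3)nc2)CC1` gives 17300 nM, the higher of the two true numbers. Compound 4 `COc1ccc(CNc2nc(Nc3ccc(N4CCN(C)CC4)cn3)ncc2Cl)cc1` differs from compound 3 by methoxy in place of hydrogen on an aromatic carbon, so benzylamino becomes (4-methoxybenzyl)amino. Going by the values given here, the step of an at least 23-fold lower number from compound 1 to compound 2 (1.36 log units; beyond the scatter) is large but lies at another place in the molecule, so no measured step bears on this change. With nothing to support a shift, the expected step of a 1.2-fold lower number from compound 3 to compound 4 (0.06 log units; within the scatter) stays within the scatter. The starting point is compound 3 at 17300 nM. For compound 4 the estimated value is 15000 nM, with an expected range of 5500 nM to 42000 nM.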

Compound 4, concentration for 50% growth inhibition: 17300 nM
For compound 4 the middle estimate is 1.2-fold (0.06 log units) below the measured one; low and high end bracket the measured number.
By their numbers in this assay, from the lowest: compound 2; then compounds 3 and 4 (each within the scatter of the next). At a limit, above all of these: compound 1.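

In this assay, methoxy in place of hydrogen on an aromatic carbon, para to a large group, gives no change at the digits printed from compound 3 to compound 4 (within the scatter). For the compounds shown here, this is the first step read on the benzyl part of the molecule, and going from benzyl to 4-methoxybenzyl leaves the growth-inhibition number where it stood, unlike the large step read at another place in the molecule. Nothing at hand bears on why this change leaves the number unmoved.

On these data alone, whether an amine, a carboxylic acid or a chlorine atom on this aromatic carbon would move the number remains open. One group at one place also cannot show whether the benzyl part as a whole is insensitive to change.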